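From Methoxy to Dimethyl on the Pendant Phenyl

A few compounds are considered here, and "the series" means these few. Any claim that something is new, unique, unknown or untested is made for them only; others in the source may bear on it.

Of the compounds shown here, three sharing one core have been measured in a functional assay on KBVIN cells (Homo sapiens) for antiproliferative activity, read by sulforhodamine B assay, with a stated time of 3 days; a higher number here means that more compound is needed for the effect, a lower number that less compound is needed. Compound 1, `CCC1=C(O)c2c(oc(-c3ccc(OC)cc3)cc2=O)C(CC)(CC)C1=O`, carries a 4-methoxyphenyl on that core and gives 0.68 uM. Compound 2, `CCC1=C(O)c2c(oc(-c3cccc(C(F)(F)F)c3)cc2=O)C(CC)(CC)C1=O`, gives 5.42 uM, and compound 3, `CCC1=C(O)c2c(oc(-c3cccc(OC(F)(F)F)c3)cc2=O)C(CC)(CC)C1=O`, gives 9.95 uM. Compound 1 therefore has the lowest number of the three; compound 2 is its nearest neighbour and compound 3 lies furthest away, both beyond the scatter. Among the compounds with values here, the one step measured between neighbours, a 1.8-fold higher number from compound 2 to compound 3 (0.26 log units; within the scatter), concerns two fluorine-bearing groups and says nothing about the methoxy group that compound 4 gives up.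

Compound 4, `CCC1=C(O)c2c(oc(-c3ccc(C)c(C)c3)cc2=O)C(CC)(CC)C1=O`, differs from compound 1 in a single place: 3,4-dimethylphenyl in place of 4-methoxyphenyl on an aromatic carbon. Within the data shown here, no measured pair shows what exchanging methoxy for methyl groups does on this core, so the step from compound 1 to compound 4 cannot be read off directly. On the numbers at hand, the two other substituted phenyls both sit well above compound 1, though neither carries a methyl group, so the dimethyl pattern is only loosely anchored. Compound 4 is therefore expected to give a moderately higher number, a 2.9-fold higher number from compound 1 to compound 4 (0.47 log units; beyond the scatter), that is, an estimated 2 uM in this assay, with a likely range from 0.6 uM to 7 uM.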

Compound 4, concentration for half-maximal effect: 0.71 uM
Beside the measured number, compound 4's estimate is 2.8-fold (0.45 log units) above it; low and high end bracket the measured number.
By their numbers in this assay, from the lowest: compounds 1 and 4 (each within the scatter of the next); then compounds 2 and 3 (each within the scatter of the next).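

Within the data shown here, the exchange of 4-methoxyphenyl for 3,4-dimethylphenyl on the aromatic carbon next to the ring oxygen gives, in this assay, a 1.0-fold higher number from compound 1 to compound 4 (0.02 log units; within the scatter), and this is the first measured step on this core that involves the methoxy group. The hydrogen-bond acceptor counted on 4-methoxyphenyl is absent from 3,4-dimethylphenyl, and the number stays within the scatter, so on this pair a group made of carbon only serves as well as the methoxy-bearing one, and compounds 1 and 4 stand together at the low end of the four numbers. Nothing measured here explains why the two groups give such similar numbers.

Among these compounds, it remains open whether both methyl groups of compound 4 matter, since a phenyl carrying only one methyl group would be needed to separate their contributions from that of the pair. Going by these compounds, it is also open how this position responds to groups of a different kind, such as an amine or a carboxylic acid on the pendant phenyl, or a longer chain in place of the methyl groups.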